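Amino in Place of Methylsulfanyl on a Shared Core

The source may report more compounds than this note shows. Statements on the series, on what has been measured and on what is new or still open speak of the compounds shown alone.

Three compounds built on one shared core were measured in a physicochemical assay for solubility, at pH 7.4; on this read-out lower numbers stand for lower solubility and higher numbers for higher solubility. Compound 1 `CSc1ccc(NC(=O)Nc2cc(C)nc3ccccc23)cc1` gives 1300 nM in this assay, the highest of the three numbers. Compound 3 `COC(=O)c1cccc(NC(=O)Nc2cc(C)nc3ccccc23)c1`, which gives 600 nM, stands nearest to it, and compound 2 `Cc1cc(NC(=O)Nc2cc(F)cc(F)c2)c2ccccc2n1`, which gives 300 nM, stands furthest; both gaps lie beyond the scatter. Compound 4 `Cc1cc(NC(=O)Nc2ccc(N)cc2)c2ccccc2n1` has not yet been measured. It differs from compound 1 in one place: amino in place of methylsulfanyl on an aromatic carbon. Among the measured compounds shown here, no measured pair shows this particular change, so what the step will do can only be expected. Compound 4 is expected to give 2500 nM, within a range from 900 nM to 7000 nM. The expected step is a 1.9-fold higher number from compound 1 to compound 4 (0.28 log units; within the scatter), an upward move that would lie beyond the scatter.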

Compound 4, solubility: 18500 nM
Estimate against measurement, compound 4: 7.4-fold (0.87 log units) below, and the stated range ends below it.
By their numbers in this assay, from the lowest: compounds 2 and 3 (each within the scatter of the next); then compound 1; then compound 4.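

In this assay, amino in place of methylsulfanyl on an aromatic carbon, para to a large group, gives a 14-fold higher number from compound 1 to compound 4 (1.15 log units; beyond the scatter) and so shows that a single change at this place can move the number by a large step. The earlier compounds shown here formed no pair differing in one place, so they could not show this. Nothing available explains the size of the step. From the compounds shown here alone, whether a hydroxyl or a dimethylamino group at this place would give a similar step remains open, as does whether amino would do the same at another place on the ring.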